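From 2-methoxyphenyl to 4-methoxypyridin-3-yl: a half-life estimate

This account rests on a few compounds, and the source may have more. Where it says the series, first, only, none or still open, it means among the compounds named here.

- compound 1 `COc1ccccc1-c1nc2c(n1C(C)C)[C@H](c1ccc(Cl)cc1C)N(c1cc(Cl)ccc1C)C2=O`: 0.06 h
- compound 2 `COc1ccc(F)cc1-c1nc2c(n1C(C)C)C(c1ccc(Cl)cc1C)N(c1cc(Cl)ccc1C)C2=O`: 0.055 h

Both numbers come from an ADME assay on microsomes from liver (Rattus norvegicus) for metabolic stability; on this read-out lower numbers stand for a shorter-lived compound and higher numbers for a longer-lived compound. Within the data shown here, compound 1 and compound 2 lie within the usual scatter of each other, so compound 1 stands level with the only other measured compound and neither can be ranked.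

Compound 3 `COc1ccncc1-c1nc2c(n1C(C)C)[C@H](c1ccc(Cl)cc1C)N(c1cc(Cl)ccc1C)C2=O` keeps the core of compound 1 and makes one change: 4-methoxypyridin-3-yl in place of 2-methoxyphenyl on an aromatic carbon, between two ring nitrogen atoms (4-methoxypyridin-3-yl in place of 2-methoxyphenyl on an aromatic carbon). Among the measured compounds shown here, no measured pair of compounds shows this change, so its size is a judgement and not a reading. A modest move towards a longer-lived compound is expected in this assay, although a result within the scatter would be no surprise. The expected step is a 1.8-fold higher number from compound 1 to compound 3 (0.26 log units; within the scatter). The estimate for compound 3 is 0.11 h, with an expected range from 0.05 h to 0.25 h.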

Compound 3, half-life: 0.2 h
Estimate against measurement, compound 3: 1.8-fold (0.26 log units) below, and the stated range covers the measured number.
By their numbers in this assay, from the lowest: compounds 2 and 1 (each within the scatter of the next); then compound 3.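

In this assay, putting 4-methoxypyridin-3-yl in place of 2-methoxyphenyl on the aromatic carbon between two ring nitrogen atoms gives a 3.3-fold higher number from compound 1 to compound 3 (0.52 log units; beyond the scatter), a step beyond the scatter. This shows that the read-out responds to the group at this position: exchanging one ring carbon for a nitrogen, with the methoxy group kept, leaves a clear mark, something the two earlier compounds, level with each other, could not show. No measurement here bears on the origin of this step, so the data give its size and nothing about its source.

A single step at this position sets no trend. As far as these compounds go, it remains open whether a pyrimidine ring, or an ethoxy group in place of the methoxy group, would move the half-life further in either direction.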